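Trimming the group on nitrogen in compound 2

The compounds below may be only part of what the source reports. "The series", "measured", "known", "first", "only" and "open" are said of these compounds alone.

In a functional assay on GOTO cells (Homo sapiens) for cytotoxicity, read by MTT assay, with a stated time of 3 days (on this read-out higher numbers stand for weaker inhibition and lower numbers for stronger inhibition), compound 2 `N#Cc1c(NNC(N)=S)nc(SCc2nc3ccccc3[nH]2)nc1-c1ccccc1` gives 2.55 nM, the lower of the two numbers, while compound 1 `N#Cc1c(Nc2ccccc2)nc(SCc2nc3ccccc3[nH]2)nc1-c1ccccc1` gives 6.41 nM. Compound 3 `N#Cc1c(NC(N)=S)nc(SCc2nc3ccccc3[nH]2)nc1-c1ccccc1` differs from compound 2 on a nitrogen on an aromatic ring: a group of 3 heavy atoms (1 carbon, 1 nitrogen, 1 sulfur; no ring) in place of a group of 4 heavy atoms (1 carbon, 2 nitrogen, 1 sulfur; no ring), on a nitrogen on an aromatic ring. Within the data shown here, the only measured step at that place is a 2.5-fold lower number from compound 1 to compound 2 (0.40 log units; beyond the scatter), modest and beyond the scatter. It removed a six-membered aromatic ring, so it offers only a loose guide here. A small upward step in this assay, near the scatter, is expected. The estimate amounts to a 1.4-fold higher number from compound 2 to compound 3 (0.14 log units; within the scatter), an expected change. For compound 3 the expected value is 3.5 nM, with an estimated range of 1.2 nM to 10 nM.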

Compound 3, half-maximal inhibitory concentration: 4.8 nM
Compound 3: the middle estimate sits 1.4-fold (0.14 log units) below what was measured, within the range that was stated.
By their numbers in this assay, from the lowest: compounds 2, 3 and 1 (each within the scatter of the next, the first and the last beyond it).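

In this assay, the group of 3 heavy atoms in place of the group of 4 heavy atoms on this nitrogen gives a 1.9-fold higher number from compound 2 to compound 3 (0.27 log units; within the scatter) and so does not separate the two groups. Against the six-membered aromatic ring of the group in compound 1, it gives a 1.3-fold lower number from compound 1 to compound 3 (0.13 log units; within the scatter) and so does not separate those two groups either; only the pair of compound 1 and compound 2 stands beyond the scatter at this place. Nothing at hand explains these numbers.
On these data alone, whether a plain amine, an acetyl group or a longer chain on this nitrogen would move the number beyond the scatter of these three compounds stays open.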